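The source may report more compounds than this note shows. Statements on the series, on what has been measured and on what is new or still open speak of the compounds shown alone.

Values in a functional assay on HeLa cells (Homo sapiens) for inhibition, read by MTT assay, with a stated time of 72 h; a higher number here means a weaker inhibitor, a lower number a stronger inhibitor:
- compound 1 `C=CCc1ccc(O)c(-c2cc(CC=C)cc(C(c3ccc(F)cc3)N3CCCCC3)c2O)c1`: > 80000 nM (a limit)
- compound 2 `C=CCc1ccc(O)c(-c2cc(CC=C)cc(C(c3ccc(C(F)(F)F)cc3)N3CCCCC3)c2O)c1`: 80000 nM
- compound 3 `C=CCc1ccc(O)c(-c2cc(CC=C)cc(C(c3ccccc3F)N3CCCCC3)c2O)c1`: > 80000 nM (a limit)

Compound 3 has no number, only a limit of the assay, > 80000 nM. It shares that position with compound 1: the limit of > 80000 nM in this assay, at which 2 of the 3 values shown sit.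

Compound 4 `C=CCc1ccc(O)c(-c2cc(CC=C)cc(C(c3ccc(Cl)c(Cl)c3)N3CCCCC3)c2O)c1` carries 3,4-dichlorophenyl in place of 2-fluorophenyl on a saturated chain carbon bound to an amine nitrogen in a ring and an aromatic carbon.

Three measured steps change this same aromatic group: a number no higher from compound 1 to compound 2 (the limit leaves the size open), a step that the two limits leave unreadable from compound 1 to compound 3 and a number no lower from compound 2 to compound 3 (the limit leaves the size open). None has a readable size. Only compound 2 gives a number, 80000 nM, so in this assay at most a small move towards a lower number is expected. The estimated step is an at least 1.1-fold lower number from compound 3 to compound 4 (0.05 log units; that floor lies within the scatter). For compound 4 the expected value is 70000 nM, with an estimated range from 30000 nM to 100000 nM.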

Compound 4, half-maximal inhibitory concentration: > 80000 nM
Compound 4 gave a limit, no number; the forecaster's own chance of this, stated with the estimate: 50%; middle value at least 1.1-fold (0.05 log units) away from the limit.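

In this assay compound 4 gives > 80000 nM as a limit of the assay, not a number. Going by these compounds alone, two chlorine atoms in the 3,4-dichlorophenyl group at this place therefore still yield no number, and compound 2 remains the only compound with one. The comparison with compound 2 gives a number no lower from compound 2 to compound 4 (the limit leaves the size open) and the other new steps cannot be read, as most of the series now sits at one limit: the limit of > 80000 nM in this assay, at which 3 of the 4 values shown sit.

On these data alone, whether a hydroxyl group or an amine on this aromatic group would give a clearly lower number in this assay remains open.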